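The source may hold more compounds than are shown below. What is called first, only, known or untested is meant among the compounds shown, and "the series" means these compounds.

Compound 1 `CCOc1ccc(NC(=O)Nc2cccc(CNc3nccnc3Cl)c2)cc1` was tested in a functional assay on MGC-803 cells (Homo sapiens) for antiproliferative activity, read by MTT assay, with a stated time of 48 h (on this read-out higher numbers stand for weaker inhibition and lower numbers for stronger inhibition), where compound 1 gives 7240 nM. Two relatives share its core and differ only in the ring on one amide-type nitrogen: compound 2 `O=C(Nc1cccc(CNc2nccnc2Cl)c1)Nc1ccc(F)c(Cl)c1` gives 5020 nM in this assay, and compound 3 `O=C(Nc1cccc(CNc2nccnc2Cl)c1)Nc1ccccc1F` gives 6440 nM. Compound 1 has the highest of the three numbers, yet all three lie within the usual scatter of one another, so no order among them can be claimed.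

Compound 4 `O=C(Nc1cccc(CNc2nccnc2Cl)c1)NC1CCCCC1` has not yet been measured. It differs from compound 1 by cyclohexyl in place of 4-ethoxyphenyl on an amide-type nitrogen. The measured steps all exchange one aromatic ring for another at this position: a 1.4-fold lower number from compound 1 to compound 2 (0.16 log units; within the scatter), a 1.1-fold lower number from compound 1 to compound 3 (0.05 log units; within the scatter) and a 1.3-fold higher number from compound 2 to compound 3 (0.11 log units; within the scatter). Within the data shown here, no measured step exchanges an aromatic ring for a non-aromatic one, so direct evidence for this change is lacking. Because a 1.4-fold lower number from compound 1 to compound 2 (0.16 log units; within the scatter) and a 1.1-fold lower number from compound 1 to compound 3 (0.05 log units; within the scatter) both stayed within the scatter, the step from compound 1 to compound 4 is expected to be small, a 1.1-fold higher number from compound 1 to compound 4 (0.04 log units; within the scatter). Compound 4 is therefore estimated at 8000 nM in this assay, with a likely range from 3500 nM to 18000 nM.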

Compound 4, half-maximal inhibitory concentration: > 40000 nM
Compound 4 gave a limit, no number; the forecaster's own chance of this, stated with the estimate: 5%; middle value at least 5.0-fold (0.69 log units) away from the limit.
By their numbers in this assay, from the lowest: compounds 2, 3 and 1 (each within the scatter of the next). At a limit, above all of these: compound 4.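

In this assay the result for compound 4 is a limit of the assay and not a number: the limit of > 40000 nM in this assay, at which 1 of the 4 values shown sits. Changing the ring on this amide-type nitrogen from aromatic to non-aromatic gives an at least 5.5-fold higher number from compound 1 to compound 4 (0.74 log units; beyond the scatter) and an at least 6.2-fold higher number from compound 3 to compound 4 (0.79 log units; beyond the scatter) and an at least 7.9-fold higher number from compound 2 to compound 4 (0.90 log units; beyond the scatter) in a position where the earlier aromatic exchanges all stayed within the scatter. The position therefore shows little response among the three aromatic rings shown, yet clearly weaker inhibition with cyclohexyl, the one non-aromatic ring here.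

With only one such ring, the compounds shown cannot separate the loss of the aromatic ring from other differences between cyclohexyl and the rings it replaces. As far as these compounds go, a cyclopentyl ring, a piperidine ring or an open hexyl chain on this nitrogen remains unexplored here, and the limit leaves the full size of the step unknown.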